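Methoxy Step in a Dienone Series: Cytotoxicity Working Notes

This account rests on a few compounds, and the source may have more. Where it says the series, first, only, none or still open, it means among the compounds named here.

Measured so far:
Compound 1 `CC(=O)/C(C)=C/c1ccc([N+](=O)[O-])cc1` gives 70500 nM
Compound 2 `C/C(=C\c1ccccc1)C(=O)/C=C/c1ccccc1` gives 34500 nM

In an ADME assay on J774.A1 cells (Mus musculus) for cytotoxicity, read by MTT assay, with a stated time of 48 h (a higher number here means that more compound is tolerated, a lower number that less compound is tolerated), compound 2 gives 34500 nM, the lowest of the two numbers shown; compound 1 gives 70500 nM, and the gap between them lies beyond the scatter. Compound 3 `COc1ccc(/C=C/C(=O)/C(C)=C/c2ccccc2)cc1` differs from compound 2 by methoxy in place of hydrogen on an aromatic carbon, sitting on an aromatic carbon of a six-membered aromatic ring of carbon only, para to a large group. Going by the values given here, no measured pair carries this change, so nothing can be read off for it; the expected step is small, likely within the scatter in either direction, a 1.1-fold lower number from compound 2 to compound 3 (0.03 log units; within the scatter). Compound 3 is therefore expected near 32000 nM, somewhere between 13000 nM and 80000 nM.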

Compound 3, half-maximal cytotoxic concentration: 51000 nM
For compound 3 the middle estimate is 1.6-fold (0.20 log units) below the measured one; the measured number falls inside the stated range.
By their numbers in this assay, from the lowest: compounds 2, 3 and 1 (each within the scatter of the next, the first and the last beyond it).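

In this assay, going by these compounds alone, methoxy in place of hydrogen on an aromatic carbon, para to a large group, gives a 1.5-fold higher number from compound 2 to compound 3 (0.17 log units; within the scatter) as the first reading for this change at this position. This position therefore takes methoxy with a step that stays inside the scatter. No measurement on hand bears on the size of this step.

Going by these compounds, whether an amine or a carboxylic acid at the same position would also stay within the scatter of compound 2 remains open. The same holds for a longer chain such as butoxy.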